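One Halogen Swap Tried on a Second Core

The compounds below may be only part of what the source reports. "The series", "measured", "known", "first", "only" and "open" are said of these compounds alone.

Of the compounds shown here, three have been measured in a functional assay on the whole organism (artery, strain albino) with Rattus norvegicus as the target, with a stated time of 15 min, at a dose of 10 mg/kg by the oral route; on this read-out lower numbers stand for less inhibition and higher numbers for more inhibition at the one dose given (going by the name of the read-out). Compound 1 `CC1=C(C(=O)Nc2ccc(Br)cc2)C(c2ccc(Cl)cc2Cl)N=C(SCc2ccc(Cl)cc2)N1` gives 4.1%, and compound 2 `CC1=C(C(=O)Nc2ccc(Br)cc2)C(c2ccc(Cl)cc2Cl)N=C(SCc2ccc(F)cc2)N1` gives 3.6%. Going by the values given here, the only change between them is fluoro in place of chloro on an aromatic carbon, and its effect was a number 0.5 percentage points lower from compound 1 to compound 2 (within the scatter). Compound 3 `CC1=C(C(=O)Nc2ccc([N+](=O)[O-])cc2)C(c2cccc([N+](=O)[O-])c2)N=C(SCc2ccc(Cl)cc2)N1` gives 2.1%; the difference between its core and the core of compound 1 is not broken down here. Compound 4 `CC1=C(C(=O)Nc2ccc([N+](=O)[O-])cc2)C(c2cccc([N+](=O)[O-])c2)N=C(SCc2ccc(F)cc2)N1` is not yet measured. It differs from compound 3 by fluoro in place of chloro on an aromatic carbon, the same change already seen between the first two compounds. Since that earlier step was a number 0.5 percentage points lower from compound 1 to compound 2 (within the scatter), a step of similar size, a number 0.1 percentage points lower from compound 3 to compound 4 (within the scatter), is expected from compound 3 to compound 4. Compound 4 is therefore estimated at 2%, most likely between -5% and 10%.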

Compound 4, a percentage reported as inhibition, in the whole organism at one dose (the size of the read-out at that dose, not a potency): 2.6%
For compound 4 the middle estimate is 0.6 percentage points below the measured one; the measured number falls inside the stated range.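

In this assay, putting fluoro in place of chloro on the second core gives a number 0.5 percentage points higher from compound 3 to compound 4 (within the scatter), so this swap makes no readable difference there. Set beside the earlier step, the change looks the same on both cores: the same change on two cores in this assay, a number 0.5 percentage points lower (within the scatter) from compound 1 to compound 2 and a number 0.5 percentage points higher (within the scatter) from compound 3 to compound 4, 1 percentage points apart, within the scatter of two such steps. Neither step stands clear of the usual scatter, however, so these pairs show only that no sizeable effect appeared on either core, and it remains unshown whether a real effect would carry from one core to the other.

The compounds shown leave open whether an amine, a carboxylic acid or a methoxy group in place of the halogen would shift the number on either core. They also leave open which of the several differences between the two cores matters, if any does.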